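Methyl to Fluoro on Two Chromanone-Type Cores

The compounds below may be only part of what the source reports. "The series", "measured", "known", "first", "only" and "open" are said of these compounds alone.

Measured so far:
- compound 1, `COc1ccc(-c2cc(=O)c3ccc(F)cc3o2)cc1`, 40%
- compound 2, `Cc1ccc([C@@H]2CC(=O)c3ccc(F)cc3O2)cc1`, "not active" (no number reported)
- compound 3, `COc1ccc(-c2cc(=O)c3ccc(C)cc3o2)cc1`, 40%

All values come from an in vitro assay on BTI-TN-5B1-4 cells for inhibition of Amine oxidase [flavin-containing] A (Homo sapiens), tested at 100 uM; on this read-out higher numbers stand for more inhibition at the one concentration tested (going by the name of the read-out) and lower numbers for less inhibition. The step of no change at the digits printed from compound 3 to compound 1 (within the scatter) is described by fluoro in place of methyl on an aromatic carbon. Compound 4, `O=C1C[C@@H](c2ccc(F)cc2)Oc2cc(F)ccc21`, has not been measured; it differs from compound 2 by fluoro in place of methyl on an aromatic carbon, the same kind of change, but here the place is para to a large group rather than meta and para to a fused ring on a fused system of two rings. The difference between the two cores is not broken down here.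

Because the step of no change at the digits printed from compound 3 to compound 1 (within the scatter) was flat, and because compound 2 was reported as "not active" (no number reported), compound 4 is expected to show a low inhibition in this assay: the estimate is 10%, with a range from 0% to 35%.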

Compound 4, a percentage reported as inhibition, at one concentration (the size of the read-out at that concentration, not a potency): "not active" (no number reported)
Compound 4: no number reported; there is nothing to compare the estimate with.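

With no number for either compound 2 or compound 4, no step can be read between them. No measurement shown bears on this result. The compounds shown leave open whether fluoro in place of methyl changes inhibition on this core.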